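The source may hold more compounds than are shown below. What is called first, only, known or untested is meant among the compounds shown, and "the series" means these compounds.

Compound 1 `O=C1N=C(N2N=C(c3ccccc3)CC2c2ccccc2O)S/C1=C1/C(=O)Nc2ccccc21`: 4730 nM
Compound 2 `O=C1N=C(N2N=C(c3ccccc3)CC2c2ccc(Cl)cc2)S/C1=C1/C(=O)Nc2ccccc21`: 6290 nM

For the measured compounds named here, in a functional assay on cells (Cancer cell lines, Homo sapiens) for cytotoxicity, read by sulforhodamine B assay, with a stated time of 48 h (a lower number here means a stronger inhibitor of growth, a higher number a weaker inhibitor of growth), compound 2 gives 6290 nM and compound 1 gives 4730 nM; the one measured step, a 1.3-fold higher number from compound 1 to compound 2 (0.12 log units; within the scatter), lies within the scatter, so the two compounds stand together rather than apart.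

Compound 3 `O=C1N=C(N2N=C(c3ccc4ccccc4c3)CC2c2ccc(Cl)cc2)S/C1=C1/C(=O)Nc2ccccc21` differs from compound 2 by naphthalen-2-yl in place of phenyl on a carbon with a double bond to nitrogen. Going by the values given here, this change sits on a carbon with a double bond to nitrogen, whereas the single measured step alters the group on a saturated ring carbon; no measured step bears on this position, and the one that exists was within the scatter in any case. With no guidance either way, a step no larger than the scatter is expected, a 1.0-fold lower number from compound 2 to compound 3 (0.02 log units; within the scatter). Compound 3 is therefore estimated at 6000 nM, with a range from 2500 nM to 15000 nM.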

Compound 3, concentration for total growth inhibition: 20900 nM
Compound 3: middle estimate off by 3.5-fold (0.54 log units), on the low side; measured number above the stated range.
By their numbers in this assay, from the lowest: compounds 1 and 2 (each within the scatter of the next); then compound 3.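

For the compounds shown here, the carbon with a double bond to nitrogen is the first position here where a change clearly moves the result in this assay. Naphthalen-2-yl in place of phenyl gives a 3.3-fold higher number from compound 2 to compound 3 (0.52 log units; beyond the scatter), so the second fused aromatic ring weakens growth inhibition in this 4-chlorophenyl series. No available evidence explains this loss.

As far as these compounds go, whether a methyl group or a 4-methoxyphenyl group at this position would retain the activity of phenyl remains open. So does whether naphthalen-2-yl would have the same effect alongside the 2-hydroxyphenyl group of compound 1.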